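A few compounds are considered here, and "the series" means these few. Any claim that something is new, unique, unknown or untested is made for them only; others in the source may bear on it.

In a functional assay on B16-F0 cells (Mus musculus) for inhibition, read by CCK-8 assay, with a stated time of 48 h (a higher number here means a weaker inhibitor, a lower number a stronger inhibitor), three compounds built on one shared core have been measured. Compound 3 (`COc1cc(-c2ccnc3cc(-c4cccc(C)c4)nn23)cc(OC)c1OC`) gives 2220 nM and is the weakest of them. Compound 1 (`COc1cc(-c2ccnc3cc(-c4ccc(C)c(C)c4)nn23)cc(OC)c1OC`) gives 391 nM and compound 2 (`COc1cc(-c2ccnc3cc(-c4ccc5cc[nH]c5c4)nn23)cc(OC)c1OC`) gives 55 nM. Compound 4 (`COc1ccc(-c2cc3nccc(-c4cc(OC)c(OC)c(OC)c4)n3n2)cc1N`) has 3-amino-4-methoxyphenyl in place of 3-methylphenyl on an aromatic carbon. Among the measured compounds shown here, three measured steps bear on this change, as each alters the same aryl group. The step of a 5.7-fold higher number from compound 1 to compound 3 (0.75 log units; beyond the scatter) is modest and comes with the loss of one methyl. The step of a 7.1-fold lower number from compound 1 to compound 2 (0.85 log units; beyond the scatter) is also modest, while the step of a 40-fold higher number from compound 2 to compound 3 (1.61 log units; beyond the scatter) is large. For the measured compounds named here, no measured compound carries an amino or methoxy group on this ring, so the size of the new step remains uncertain. Still, both other aryl groups give lower numbers than compound 3 does at 2220 nM, and the gap to compound 2 shows how far a change of this group can reach. A large step towards a lower number is therefore expected, and the expected step is a 37-fold lower number from compound 3 to compound 4 (1.57 log units; beyond the scatter). Compound 4 is estimated at 60 nM, with an expected range from 12 nM to 350 nM.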

Compound 4, half-maximal inhibitory concentration: 88 nM
Beside the measured number, compound 4's estimate is 1.5-fold (0.17 log units) below it; the range from low to high includes it.
By their numbers in this assay, from the lowest: compounds 2 and 4 (each within the scatter of the next); then compound 1; then compound 3.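

Compound 4 shows that, in this assay, a low number at this aromatic carbon of the five-membered ring does not depend on the fused 1H-indol-6-yl group, since a single substituted phenyl ring also gives one. Putting 3-amino-4-methoxyphenyl in place of 3-methylphenyl gives a 25-fold lower number from compound 3 to compound 4 (1.40 log units; beyond the scatter), and putting it in place of 3,4-dimethylphenyl gives a 4.4-fold lower number from compound 1 to compound 4 (0.65 log units; beyond the scatter), whereas against 1H-indol-6-yl the change gives a 1.6-fold higher number from compound 2 to compound 4 (0.20 log units; within the scatter), so these two groups cannot be told apart here. Among these four compounds, the two aryl groups that hold a nitrogen, in compound 2 and compound 4, give lower numbers than the two methyl-bearing phenyl groups of compound 1 and compound 3, and none of the four goes against this.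

The compounds shown leave open whether the amine or the methoxy group carries the step, as neither appears alone on this ring, and how a 3-hydroxy-4-methoxyphenyl or a 3-(dimethylamino)-4-methoxyphenyl group would read in this assay. Nothing available gives a reason for these differences.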